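Swapping benzyloxy for bromophenyl on a non-cytotoxic scaffold

The source may report more compounds than this note shows. Statements on the series, on what has been measured and on what is new or still open speak of the compounds shown alone.

Measured compounds:
compound 1, `C=C[C@@](C)(/C=C/c1ccc(OCc2ccccc2)cc1)CCC=C(C)C`: > 36600 nM
compound 2, `COc1ccc(/C=C/[C@@](C)(/C=C/c2ccc(O)c(/C=C/C(=O)OCc3ccccc3)c2)CCC=C(C)C)cc1`: > 36600 nM

Both compounds were tested in an ADME assay on BJ cells (Homo sapiens) for cytotoxicity, with a stated time of 72 h; a higher number here means that more compound is needed for the effect, a lower number that less compound is needed. For compound 1 the result in this assay is > 36600 nM, which is a limit of the assay rather than a number. Compound 2 likewise gives > 36600 nM in this assay, again a limit and not a number. So compound 1 stands at the limit of > 36600 nM in this assay, at which 2 of the 2 values shown sit; nothing finer than that is known about it, and no measured step between two compounds exists to lean on.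

Compound 3, `C=C[C@@](C)(/C=C/c1ccc(-c2cccc(Br)c2)cc1)CCC=C(C)C`, differs from compound 1 in a single place: 3-bromophenyl in place of benzyloxy on an aromatic carbon. Since every value seen so far sits at the same limit, there is no sign in these data that a change on this part of the shared core moves the cytotoxicity read-out at all. The expected step from compound 1 to compound 3 is therefore a number no higher from compound 1 to compound 3 (the limit leaves the size open), none beyond the scatter. Compound 3 is estimated to give 36600 nM, in a range from 15000 nM to 90000 nM, and most likely the assay will again return only a limit.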

Compound 3, half-maximal effective concentration: > 36600 nM
Compound 3: no number, only a limit (the forecaster's own chance of this, stated with the estimate: 70%); the middle value sits exactly at the limit.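

In this assay compound 3 gives > 36600 nM, which is a limit of the assay and not a number. Among these compounds, compound 1 also ends at a limit, and no step from compound 1 to compound 3 can be read. The compounds shown leave open what concentration of any of them would produce cytotoxicity, and whether 3-bromophenyl and benzyloxy differ at all.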